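The source may report more compounds than this note shows. Statements on the series, on what has been measured and on what is new or still open speak of the compounds shown alone.

Measured in a functional assay on HBL-100 cells (Homo sapiens) for antiproliferative activity, read by sulforhodamine B assay, with a stated time of 48 h; a lower number here means a stronger inhibitor of growth, a higher number a weaker inhibitor of growth:

- compound 1 `CCCCC(C#CC(=O)OC)O/C=C/C(=O)OC`: 250 nM
- compound 2 `CCOC(=O)C#CC(O/C=C/C(=O)OCC)C(C)C`: 3000 nM
- compound 3 `COC(=O)C#CC(O/C=C/C(=O)OC)C1CCCCC1`: 2500 nM

Compound 3 stands at the weak end of this small set in this assay. Compound 3 at 2500 nM lies within the usual scatter of compound 2 at 3000 nM, while compound 1 lies well apart at 250 nM.

The next compound, compound 4 `COC(=O)C#CC(O/C=C/C(=O)OC)C1CC1`, carries cyclopropyl in place of cyclohexyl on a saturated chain carbon bound to an oxygen on an unsaturated carbon and a triple-bonded carbon.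

Among the compounds with values here, one measured step bears directly on this place: a 10-fold higher number from compound 1 to compound 3 (1.00 log units; beyond the scatter). It shows that a change here can move the number beyond the scatter, but it replaces butyl, not a ring, so it gives no direct measure for the change from cyclohexyl to cyclopropyl. Compound 3 differs from compound 2 in more than one place, so compound 2 offers only a loose reference at 3000 nM. Within the data shown here, no measured compound carries a ring smaller than cyclohexyl here, so the forecast stays cautious, with no shift beyond the scatter expected and a slight lean toward a lower number.

The expected step is a 1.4-fold lower number from compound 3 to compound 4 (0.14 log units; within the scatter). For compound 4 the estimated value is 1800 nM, with an expected range from 500 nM to 5000 nM.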

Compound 4, concentration for 50% growth inhibition: 250 nM
Compound 4: the middle estimate sits 7.2-fold (0.86 log units) above what was measured, outside the stated range (below it).
By their numbers in this assay, from the lowest: compounds 1 and 4 (each within the scatter of the next); then compounds 3 and 2 (each within the scatter of the next).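

In this assay, cyclopropyl in place of cyclohexyl on the saturated chain carbon bound to an oxygen on an unsaturated carbon and a triple-bonded carbon gives a 10-fold lower number from compound 3 to compound 4 (1.00 log units; beyond the scatter), so a ring at this place does not by itself go with the higher number, which the earlier comparison of butyl with cyclohexyl could not show. Cyclopropyl in place of butyl gives no change at the digits printed from compound 1 to compound 4 (within the scatter), so among the three compounds that can be compared at this place, a small ring and an open chain stand together and cyclohexyl alone stands apart. Nothing available accounts for this difference between the two rings.

With only the three-membered and six-membered rings shown, it remains open whether cyclobutyl or cyclopentyl at this place would fall with compound 4 or with compound 3. Going by these compounds, it also remains open whether a phenyl ring or a chain longer than butyl would stay with compound 1 or move toward compound 3.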